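The compounds below may be only part of what the source reports. "The series", "measured", "known", "first", "only" and "open" are said of these compounds alone.

In a functional assay on U-87MG ATCC cells (Homo sapiens) for antiproliferative activity (a higher number here means a weaker inhibitor, a lower number a stronger inhibitor), compound 1, `Cc1c2c(n3c1CCCN[C@@H](C)[C@H](C)Nc1cc-3ccc1C(N)=O)CC(C)(C)CC2=O`, gives 61 nM. Compound 2, `Cc1c2c(n3c1CCNC[C@@H](C)[C@H](C)Nc1cc-3ccc1C(N)=O)CC(C)(C)CC2=O`, gives 40 nM. These two numbers lie within the scatter of each other, so they cannot be ranked, and compound 2 simply stands among the double-digit nanomolar values seen so far in this cell test.

Compound 3, `Cc1c2c(n3c1CCN(C(=O)CN)C[C@@H](C)[C@H](C)Nc1cc-3ccc1C(N)=O)CC(C)(C)CC2=O`, departs from compound 2 at a single place: (aminomethyl)carbonyl in place of hydrogen on an amine nitrogen in a ring. The counted difference is (aminomethyl)carbonyl in place of hydrogen on an amine nitrogen in a ring. That nitrogen thus goes from carrying a hydrogen to carrying a small chain that ends in an amine.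

Among the measured compounds shown here, no measured pair shows what a substituent at this nitrogen does to the read-out, so the expectation rests on little and the range has to stay wide. A small shift towards a weaker number is the best guess, possibly no shift beyond the scatter. The expected change is a 1.5-fold higher number from compound 2 to compound 3 (0.18 log units; within the scatter). For compound 3 the estimated value is 60 nM, with an expected range from 15 nM to 250 nM.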

Compound 3, half-maximal inhibitory concentration: 378 nM
The estimate for compound 3 lay 6.3-fold (0.80 log units) below the measured number; the whole stated range lies below it.
By their numbers in this assay, from the lowest: compounds 2 and 1 (each within the scatter of the next); then compound 3.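

Among the compounds shown here, the pair gives the first reading of what a substituent on this amine nitrogen does: in this assay putting (aminomethyl)carbonyl in place of hydrogen gives a 9.5-fold higher number from compound 2 to compound 3 (0.98 log units; beyond the scatter) and so makes the compound a clearly weaker inhibitor. This nitrogen in the non-aromatic ring is therefore not a place where any added group leaves the read-out unchanged, since this group of four heavy atoms shifts it well past the ordinary variation between repeated tests. Nothing measured here explains the shift, and the data show only that it happens, not how it arises.

A single substituent leaves open whether the weaker number goes with the carbonyl on the ring nitrogen or with the amine at the end of the added chain, and a plain acetyl group, which keeps the carbonyl and lacks that amine, would help separate the two. On these data alone, it is equally open how a simple methyl group on this nitrogen, or a longer chain ending in an amine or a carboxylic acid, would compare with the hydrogen of compound 2.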